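Replacing 2-Iodophenyl with 4-Methylphenyl on the Carbonyl

A few compounds are considered here, and "the series" means these few. Any claim that something is new, unique, unknown or untested is made for them only; others in the source may bear on it.

Among the measured compounds shown here, compound 2 `NC(=O)c1c(NC(=O)c2ccccc2I)sc2c1CCN(C(=S)Nc1ccccc1Cl)C2` holds the lower of the two numbers measured so far in a functional assay on HL-60 cells (Homo sapiens) for antiproliferative activity, with a stated time of 24 h; a lower number here means a stronger inhibitor, a higher number a weaker inhibitor: compound 2 gives 8560 nM, whereas compound 1 `NC(=O)c1c(NC(=O)c2ccccc2Cl)sc2c1CCN(Cc1ccccc1F)C2` gives 21800 nM, a gap beyond the usual scatter. Compound 3 `Cc1ccc(C(=O)Nc2sc3c(c2C(N)=O)CCN(C(=S)Nc2ccccc2Cl)C3)cc1` keeps the core of compound 2 and carries a single change: 4-methylphenyl in place of 2-iodophenyl on a carbonyl carbon. For the measured compounds named here, no measured pair of compounds shows this exchange on its own, so its effect cannot be read from the data. Both measured compounds are weak inhibitors, and nothing in their two numbers points to a large shift from exchanging one aromatic group for the other. Compound 3 is therefore expected to land near compound 2, with the step of a 1.4-fold higher number from compound 2 to compound 3 (0.15 log units; within the scatter) estimated as a small loss or none beyond the scatter. The estimate for compound 3 is 12000 nM, within a range from 4000 nM to 35000 nM.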

Compound 3, half-maximal inhibitory concentration: 8430 nM
Beside the measured number, compound 3's estimate is 1.4-fold (0.15 log units) above it, and the stated range covers the measured number.
By their numbers in this assay, from the lowest: compounds 3 and 2 (each within the scatter of the next); then compound 1.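

In this assay, the exchange of 2-iodophenyl for 4-methylphenyl on a carbonyl carbon gives a 1.0-fold lower number from compound 2 to compound 3 (0.01 log units; within the scatter) and leaves the two compounds indistinguishable. Among the compounds shown here, this is the first direct reading at this position: with the rest of the molecule held fixed, either aromatic group gives a number within the usual scatter, so the iodine is not needed to keep this weak level of activity. No measurement on hand explains why the two groups read alike.

The exchange alters both the atom on the ring and its place, so this single step cannot separate those two changes, and a compensating effect cannot be ruled out. On these data alone, how the position responds to something other than a substituted phenyl ring, such as an amine, a carboxylic acid or a longer chain, remains open.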